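Diphenylacetamide piperazines: arylpiperazine variation in vivo

The source may report more compounds than this note shows. Statements on the series, on what has been measured and on what is new or still open speak of the compounds shown alone.

Measured so far:
compound 1 `COc1ccccc1N1CCN(CC(=O)N(c2ccccc2)c2ccccc2)CC1` gives 12.7 mg/kg in a functional assay on the whole organism (strain Swiss albino) for inhibition, with Mus musculus as the target, with stated times of 30 min, 10 min and 20 min; on this read-out lower numbers stand for an effect already at smaller amounts and higher numbers for an effect only at larger amounts of compound
compound 2 `COc1cccc(N2CCN(CC(=O)N(c3ccccc3)c3ccccc3)CC2)c1` gives 15.5 mg/kg in this assay
compound 3 `O=C(CN1CCN(c2cccc(Cl)c2)CC1)N(c1ccccc1)c1ccccc1` gives 18 mg/kg in this assay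

Compound 3 has the highest of the three numbers in this assay; its nearest neighbour is compound 2 and its furthest is compound 1, and both gaps lie within the scatter, so the three compounds cannot be ordered.

Compound 4 `O=C(CN1CCN(c2ccc([N+](=O)[O-])cc2)CC1)N(c1ccccc1)c1ccccc1` is not yet measured. The change from compound 3 is 4-nitrophenyl in place of 3-chlorophenyl on an amine nitrogen in a ring. The three measured steps all exchange the group on the same ring nitrogen or a substituent on it: a 1.2-fold higher number from compound 1 to compound 2 (0.09 log units; within the scatter), a 1.4-fold higher number from compound 1 to compound 3 (0.15 log units; within the scatter) and a 1.2-fold higher number from compound 2 to compound 3 (0.06 log units; within the scatter). None of them left the scatter. For the measured compounds named here, no measured step brings in a nitro group, so the change to compound 4 has no direct precedent, but every change so far on this position has been silent in this assay. The step of a 1.1-fold higher number from compound 3 to compound 4 (0.02 log units; within the scatter) is therefore expected to be small, in no particular direction beyond the scatter. Compound 4 is estimated at 19 mg/kg, with a range from 9 mg/kg to 42 mg/kg, the upper end widened because compound 3 already stands at 18 mg/kg.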

Compound 4, dose for half-maximal effect: > 40 mg/kg
Compound 4 ended at the assay's limit (the forecaster's own chance of this, stated with the estimate: 10%); middle value at least 2.1-fold (0.32 log units) away from the limit.
By their numbers in this assay, from the lowest: compounds 1, 2 and 3 (each within the scatter of the next). At a limit, above all of these: compound 4.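

In this assay compound 4 sits at a limit of the read-out, not at a number: the limit of > 40 mg/kg in this assay, at which 1 of the 4 values shown sits.

For the compounds shown here, this is the first change on the ring nitrogen that leaves the scatter. The new steps are an at least 2.2-fold higher number from compound 3 to compound 4 (0.34 log units; beyond the scatter), an at least 2.5-fold higher number from compound 2 to compound 4 (0.41 log units; beyond the scatter) and an at least 3.1-fold higher number from compound 1 to compound 4 (0.49 log units; beyond the scatter), all read against that limit, while exchanges among 2-methoxyphenyl, 3-methoxyphenyl and 3-chlorophenyl stayed within the scatter. Going by these compounds alone, the group on this nitrogen therefore matters in this read-out, and the series does not tolerate every aryl group there equally, as 4-nitrophenyl is the one group of the four set apart from the others.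

Compound 4 alone carries a nitro group and alone a substituent numbered 4 on the phenyl ring, so the two features cannot be told apart here. Open, as far as these compounds go, is how 3-nitrophenyl and 4-chlorophenyl on the same nitrogen would read, and how far compound 4 lies past its limit.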